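Carbamoyl variation: butyl in place of cyclohexyl

The source may hold more compounds than are shown below. What is called first, only, known or untested is meant among the compounds shown, and "the series" means these compounds.

Compound 1 `O=C(C1CCCCC1)N1CCCN(C(c2ccccc2)c2ccccc2)CC1` carries a cyclohexyl on a carbonyl carbon. In an assay on isolated protein for binding affinity to Neuromedin-U receptor 1 (Homo sapiens) (a lower number here means a stronger inhibitor, a higher number a weaker inhibitor), compound 1 gives only a limit, < 10000 nM. Compound 2 `O=C(NC1CCCCC1)N1CCCN(C(c2ccccc2)c2ccccc2)CC1` has cyclohexylamino in place of that cyclohexyl. In this assay compound 2 likewise gives only a limit, < 10000 nM. The step that the two limits leave unreadable from compound 1 to compound 2 is thus not readable, as the limit of < 10000 nM in this assay, at which 2 of the 2 values shown sit, shows. Compound 3 `CCCCNC(=O)N1CCCN(C(c2ccccc2)c2ccccc2)CC1` differs from compound 2 by butyl in place of cyclohexyl on an amide-type nitrogen. Within the data shown here, no measured step bears on this change, so the step that the limit leaves unreadable from compound 2 to compound 3 is expected to be near zero with no direction. Compound 3 is estimated at 2000 nM, within 200 nM to 10000 nM, and another limit-only reading is likely.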

Compound 3, inhibition constant: < 10000 nM
Compound 3: no number, only a limit; the forecaster's own chance of this, stated with the estimate: 60%; the middle value is on the limit's open side.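

No step among compound 1, compound 2 and compound 3 can be read, since all three give only a limit: the limit of < 10000 nM in this assay, at which 3 of the 3 values shown sit.

The compounds shown leave open where each true inhibition constant lies and whether butyl in place of cyclohexyl changes it at all.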